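The compounds below may be only part of what the source reports. "The series", "measured", "known", "first", "only" and "open" are said of these compounds alone.

Measured so far:
compound 1, `COc1ccc(S(=O)(=O)c2cnc3c(F)cccc3c2-c2cccc(F)c2)cc1`, 3.03 mL/min in an ADME assay on microsomes from liver (Homo sapiens) for metabolic stability, tested at 2.5 uM; on this read-out higher numbers stand for fast clearance and lower numbers for slow clearance
compound 2, `COc1cccc(-c2c(S(=O)(=O)c3cc(F)cc(F)c3)cnc3cc(F)ccc23)c1`, 1.81 mL/min in this assay
compound 3, `O=S(=O)(c1cc(F)cc(F)c1)c1cnc2cc(F)ccc2c1-c1cccc(F)c1`, 0.06 mL/min in this assay

Compounds 2 and 3 differ in one place: fluoro in place of methoxy on an aromatic carbon. That single change brought a 30-fold lower number from compound 2 to compound 3 (1.48 log units; beyond the scatter), a large step, so this assay responds strongly to it. Compound 1 and compound 2 do not share this simple relationship; how their two cores differ is not broken down here. Compound 1 sits highest of the three numbers, though its gap to compound 2 stays within the usual scatter, while its gap to compound 3 lies beyond it.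

Compound 4, `O=S(=O)(c1ccc(F)cc1)c1cnc2c(F)cccc2c1-c1cccc(F)c1`, has not yet been measured. It differs from compound 1 in one place: fluoro in place of methoxy on an aromatic carbon. Among the compounds with values here, this is the same kind of change as the one from compound 2 to compound 3, but not the same: there the fluoro sits meta to a large group, here para to a large group. Because the change gave a 30-fold lower number from compound 2 to compound 3 (1.48 log units; beyond the scatter), a step of similar direction is expected, though its size is uncertain, giving an estimate of a 10-fold lower number from compound 1 to compound 4 (1.00 log units; beyond the scatter) from compound 1. Compound 4 is therefore expected to give about 0.3 mL/min, plausibly between 0.05 mL/min and 1.5 mL/min.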

Compound 4, intrinsic clearance in a liver preparation (reported as CLH), per the amount of preparation that the assay uses: 1.56 mL/min
Compound 4: middle estimate off by 5.2-fold (0.72 log units), on the low side; the measured number lies above the stated range.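

In this assay, replacing methoxy with fluoro on the core of compound 1, the change from 4-methoxyphenyl to 4-fluorophenyl, gave a 1.9-fold lower number from compound 1 to compound 4 (0.29 log units; within the scatter) and so did not repeat the large step seen on the other core. The same change therefore had a different size on these two cores: the same change on two cores in this assay, a 30-fold lower number (1.48 log units; beyond the scatter) from compound 2 to compound 3 and a 1.9-fold lower number (0.29 log units; within the scatter) from compound 1 to compound 4, 16-fold (1.19 log units) apart, beyond the scatter of two such steps. This shows that, within this series, a step measured on one core is no safe guide to its size on another, but two pairs cannot show whether the gap comes from the place of the group on its ring or from the other differences between the cores.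

The compounds shown leave open how the change would behave on further cores, and whether a small step or a large one would be the more usual result. They also leave open what other groups in the same place, such as an amine, a nitrile or a carboxylic acid, would do to clearance on either core.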